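The source may hold more compounds than are shown below. What is called first, only, known or untested is meant among the compounds shown, and "the series" means these compounds.

Measured compounds:
- compound 1 `COc1ccc2ncc(-c3nn[nH]n3)cc2c1` — > 25 mg/kg, a limit of the assay
- compound 2 `FC(F)(F)c1ccc2cc(-c3nn[nH]n3)cnc2c1` — 25 mg/kg
- compound 3 `O=c1c(-c2nn[nH]n2)c[nH]c2c(C(F)(F)F)cccc12` — > 25 mg/kg, a limit of the assay

The read-out is a functional assay on the whole organism (strain Sprague-Dawley) for inhibition, with Rattus norvegicus as the target; on this read-out higher numbers stand for an effect only at larger amounts of compound and lower numbers for an effect already at smaller amounts. Compound 3 stands at the limit of > 25 mg/kg in this assay, at which 2 of the 3 values shown sit, so only a limit and no number is known for it. Compound 1 also returns a limit in this assay. Compound 2 returns a number in this assay, and it sits at the edge of the dose range where the other two stop.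

Compound 4 `COc1cccc2c(=O)c(-c3nn[nH]n3)c[nH]c12` is not yet measured. It differs from compound 3 in one place: methoxy in place of trifluoromethyl on an aromatic carbon. Among the measured compounds shown here, no step between measured compounds is available for this change, and compound 3 itself is known only as a limit, so the size of the step cannot be anchored. Compound 1 carries the same methoxy group and also stops at the limit, which gives no sign of a gain. The step from compound 3 to compound 4 is therefore expected to be none beyond the scatter, a step that the limit leaves unreadable from compound 3 to compound 4. For compound 4 the expected value in this assay is 35 mg/kg, within the range 15 mg/kg to 90 mg/kg, and a limit rather than a number is the more likely outcome.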

Compound 4, minimum effective dose: 0.312 mg/kg
Compound 4: the middle estimate sits 110-fold (2.05 log units) above what was measured; measured number below the stated range.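

In these notes on the series, the group on this aromatic carbon makes a large difference in this assay: methoxy in place of trifluoromethyl gives an at least 80-fold lower number from compound 3 to compound 4 (1.90 log units; beyond the scatter). Among the compounds shown here, the earlier compounds offered no pair differing in one place, so this is the first sign that a single change at this position can move the read-out, and it rests on this one pair alone. The step is only a bound, because compound 3 stands at a limit and not at a number: the limit of > 25 mg/kg in this assay, at which 2 of the 4 values shown sit.

As far as these compounds go, the true size of the step stays unknown, and so does whether the effect is specific to methoxy or would also appear with hydrogen, a hydroxyl or an ethoxy on the same carbon. The compounds shown also leave open whether a longer chain, such as a propoxy, or an amine at this position would hold the low dose seen for compound 4.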